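Acetylating a hydroxy group of compound 3

The source may hold more compounds than are shown below. What is called first, only, known or untested is meant among the compounds shown, and "the series" means these compounds.

Compound 1 `C=C1CC[C@@H]2[C@](C)(COC(C)=O)[C@H](OC(C)=O)CC[C@@]2(C)[C@@H]1C/C=C1/C(=O)OC[C@H]1OC(C)=O`: 11.4 uM
Compound 2 `C=C1CC[C@@H]2[C@](C)(CO[Si](C)(C)C(C)(C)C)[C@H](O)CC[C@@]2(C)[C@@H]1C/C=C1/C(=O)OC[C@H]1OC(C)=O`: 3.41 uM
Compound 3 `C=C1CC[C@@H]2[C@](C)(COC(C)=O)[C@H](O)CC[C@@]2(C)[C@@H]1C/C=C1/C(=O)OC[C@H]1O`: 16.7 uM

All three values come from a functional assay on ASK cells (Rattus norvegicus) for cytotoxicity, read by sulforhodamine B assay; on this read-out higher numbers stand for an effect only at larger amounts of compound and lower numbers for an effect already at smaller amounts. Compound 3, at 16.7 uM, lies within the scatter of compound 1 at 11.4 uM. The gap between compound 3 and compound 2 at 3.41 uM is beyond the scatter, with compound 3 carrying the higher number.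

Compound 4 `C=C1CC[C@@H]2[C@](C)(COC(C)=O)[C@H](O)CC[C@@]2(C)[C@@H]1C/C=C1/C(=O)OC[C@H]1OC(C)=O` is the next structure to consider. The change from compound 3 is acetyl in place of hydrogen on an oxygen on a saturated carbon, with acetyl in place of hydrogen on an oxygen on a saturated carbon, hydroxy to acetoxy.

Among the compounds with values here, no measured pair differing in one place is available to size this change in this assay. Compound 1 also carries acetoxy at that place, and its 11.4 uM is within the scatter of compound 3, so no step beyond the scatter is expected. The estimated 1.3-fold lower number from compound 3 to compound 4 (0.11 log units; within the scatter) therefore stays within the scatter. For compound 4 the expected value is 13 uM, with an estimated range of 6.5 uM to 25 uM.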

Compound 4, concentration for half-maximal effect: 16.3 uM
Compound 4: middle estimate off by 1.3-fold (0.10 log units), on the low side; low and high end bracket the measured number.
By their numbers in this assay, from the lowest: compound 2; then compounds 1, 4 and 3 (each within the scatter of the next).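

In this assay, hydroxy to acetoxy at this position gives a 1.0-fold lower number from compound 3 to compound 4 (0.01 log units; within the scatter), the first direct measure of this change, and acetyl on this oxygen makes no difference beyond the scatter. Within the data shown here, removing acetyl from a different oxygen gives a step of the same kind, a 1.4-fold higher number from compound 1 to compound 4 (0.16 log units; within the scatter), whereas acetyl in place of tert-butyldimethylsilyl on a third oxygen gives a 4.8-fold higher number from compound 2 to compound 4 (0.68 log units; beyond the scatter), the only new step beyond the scatter. Nothing measured here offers an explanation for these steps.

Going by these compounds, whether this position tolerates groups other than acetyl, such as a methyl ether or a longer acyl chain like hexanoyl, remains open. Also open, on these data alone, is whether the step from tert-butyldimethylsilyl depends on silicon or would also appear with an all-carbon chain on that oxygen.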